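The compounds below may be only part of what the source reports. "The series", "measured", "known", "first", "only" and "open" are said of these compounds alone.

Measured so far in a physicochemical assay for solubility, with a stated time of 18 h, at pH 7.4; a higher number here means a more soluble compound, a lower number a less soluble compound:
- compound 1 `COc1cccc(CNCCCNc2ccnc3cc(-c4ccc(C(F)(F)F)cc4)ccc23)c1O`: 32000 nM
- compound 2 `COc1cccc(CNCCCNc2ccnc3cc(Oc4cccc(N(C)C)c4)ccc23)c1O`: 14500 nM

Going by the values given here, compound 2 stands lowest of the two numbers; the one measured step, a 2.2-fold lower number from compound 1 to compound 2 (0.34 log units; beyond the scatter), separates it from compound 1. Compound 3 `COc1cccc(CNCCCNc2ccnc3cc(Cc4ccc(F)cc4Cl)ccc23)c1O` differs from compound 2 by 2-chloro-4-fluorobenzyl in place of 3-(dimethylamino)phenoxy on an aromatic carbon. Among the compounds with values here, no measured step covers this exchange; the step from compound 1 to compound 2 concerns a different pair of groups and only shows that a change at this position can move this assay modestly. Compound 3 is therefore expected near compound 2, with a 1.4-fold higher number from compound 2 to compound 3 (0.14 log units; within the scatter) as the estimated step. The estimate for compound 3 is 20000 nM, range 7000 nM to 60000 nM.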

Compound 3, solubility: 4200 nM
The estimate for compound 3 lay 4.8-fold (0.68 log units) above the measured number; measured number outside the range, below it.
By their numbers in this assay, from the lowest: compound 3; then compound 2; then compound 1.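

In this assay, going by these compounds alone, the 2-chloro-4-fluorobenzyl group gives a 3.5-fold lower number from compound 2 to compound 3 (0.54 log units; beyond the scatter) against 3-(dimethylamino)phenoxy, and against 4-(trifluoromethyl)phenyl it gives a 7.6-fold lower number from compound 1 to compound 3 (0.88 log units; beyond the scatter) as the widest step at this position so far. The position on the shared core therefore tolerates larger shifts in this read-out than the earlier step showed. Nothing available explains the drop. Each exchange alters the link to the ring and the ring substituents together, so their separate contributions remain unresolved. Also open, as far as these compounds go, is how a benzyl group carrying an amine or a carboxylic acid would read here.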